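This account rests on a few compounds, and the source may have more. Where it says the series, first, only, none or still open, it means among the compounds named here.

Working notes on the series. Among the measured compounds shown here, compound 2 `CC(C(=O)NCc1cc(C(C)(C)C)nn1-c1ccc(C(F)(F)F)cc1)c1ccc2c(c1)CCC2` in an assay on CHO-K1 cells for antagonist activity at transient receptor potential cation channel subfamily V member 1 (Homo sapiens), read by FLIPR (a lower number here means a stronger inhibitor, a higher number a weaker inhibitor), gives 62.4 nM, the highest of the two numbers measured so far. Its nearest neighbour is compound 1 `CC(C(=O)NCc1cc(C(F)(F)F)nn1-c1ccc(OC(F)(F)F)cc1)c1ccc2c(c1)CCC2`, which in this assay gives 51.6 nM; the gap between the two lies within the scatter, so no order between them is claimed. For the measured compounds named here, compound 1 differs from compound 2 in two places at once, so no single-point step between measured compounds is available.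

Compound 3 `CC(C(=O)NCc1cc(C(C)(C)C)nn1-c1ccc(OC(F)(F)F)cc1)c1ccc2c(c1)CCC2` is not yet measured. It differs from compound 2 only by trifluoromethoxy in place of trifluoromethyl on an aromatic carbon. Compound 1 already carries the trifluoromethoxy group and sits within the scatter of compound 2, which suggests the change is unlikely to move the number far. The expected step from compound 2 to compound 3 is a 1.2-fold lower number from compound 2 to compound 3 (0.10 log units; within the scatter), no larger than the scatter. Compound 3 is thus estimated at 50 nM in this assay, with a range from 20 nM to 125 nM.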

Compound 3, inhibition constant: 65.9 nM
For compound 3 the middle estimate is 1.3-fold (0.12 log units) below the measured one; measured number inside the range.
By their numbers in this assay, from the lowest: compounds 1, 2 and 3 (each within the scatter of the next).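

In this assay, the change from 4-(trifluoromethyl)phenyl to 4-(trifluoromethoxy)phenyl can now be read on its own, with tert-butyl held constant: a 1.1-fold higher number from compound 2 to compound 3 (0.02 log units; within the scatter), so this exchange leaves the number within the scatter. A second single-point reading holds 4-(trifluoromethoxy)phenyl constant and places tert-butyl in place of trifluoromethyl on an aromatic carbon: a 1.3-fold higher number from compound 1 to compound 3 (0.11 log units; within the scatter), also within the scatter. No further measurement bears on these two steps.

The compounds shown leave open whether a group of another kind, such as an amine or a carboxylic acid, in place of trifluoromethoxy would stay within the scatter of these values. Also open, as far as these compounds go, is whether a longer chain in place of tert-butyl would do the same.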